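Ring size on the indole nitrogen and rat exposure

The source may report more compounds than this note shows. Statements on the series, on what has been measured and on what is new or still open speak of the compounds shown alone.

Measured compounds:
compound 1 `CC(C)(C)S(=O)(=O)Nc1ccc(-c2c(C(N)=O)c3cc(F)c(OC(F)F)cc3n2C2CCCCC2)c(Cl)c1` 1200 ng.h/mL
compound 2 `CC(C)(C)S(=O)(=O)Nc1ccc(-c2c(C(N)=O)c3cc(F)c(OC(F)F)cc3n2-c2ccccc2)cc1` 7670 ng.h/mL
compound 3 `CC(C)(C)S(=O)(=O)Nc1ccc(-c2c(C(N)=O)c3cc(F)c(OC(F)F)cc3n2C2CCCC2)cc1` 200 ng.h/mL

In an ADME assay on the whole organism (plasma, strain Sprague-Dawley) for pharmacokinetics, with Rattus norvegicus as the target, with stated times of 6 h and 30 min, at a dose of 10 mg/kg by the oral route (a lower number here means less compound in the circulation, a higher number more compound in the circulation at the dose given), compound 3 stands lowest of the three; compound 1 gives 1200 ng.h/mL and compound 2 gives 7670 ng.h/mL. Compound 4 `CC(C)(C)S(=O)(=O)Nc1ccc(-c2c(C(N)=O)c3cc(F)c(OC(F)F)cc3n2C2CCCCC2)cc1` is yet to be measured. The change is cyclohexyl in place of cyclopentyl on an aromatic nitrogen. Among the measured compounds shown here, the only measured step at that position, a 38-fold lower number from compound 2 to compound 3 (1.58 log units; beyond the scatter), swaps an aromatic ring for a saturated one, which is not the same as adding one carbon to a saturated ring. Compound 1 carries the cyclohexyl group with an extra chlorine on the phenyl ring, so its value shows only loosely where compound 4 may fall. Compound 4 is expected to rise moderately, a 3.0-fold higher number from compound 3 to compound 4 (0.48 log units; beyond the scatter), to an estimated 600 ng.h/mL (range 200 ng.h/mL to 2000 ng.h/mL).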

Compound 4, area under the concentration-time curve: 447 ng.h/mL
Beside the measured number, compound 4's estimate is 1.3-fold (0.13 log units) above it; measured number inside the range.
By their numbers in this assay, from the lowest: compound 3; then compound 4; then compound 1; then compound 2.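

In this assay one more carbon in the saturated ring gives only a 2.2-fold higher number from compound 3 to compound 4 (0.35 log units; beyond the scatter) while cyclohexyl in place of phenyl gives a 17-fold lower number from compound 2 to compound 4 (1.23 log units; beyond the scatter) so changing the size of the saturated ring moves this number far less than leaving the phenyl does. Hydrogen in place of chloro on an aromatic carbon gives a 2.7-fold lower number from compound 1 to compound 4 (0.43 log units; beyond the scatter) so that change also moves the number when cyclohexyl is present. Nothing shown explains these steps.

As far as these compounds go, whether a smaller cyclobutyl or an aromatic pyridyl ring on this nitrogen would come closer to phenyl remains open. So does whether a chloro group would have a similar effect with phenyl present.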